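Chloro to fluoro on the aryl ring of a triazolopyrimidine thione

A few compounds are considered here, and "the series" means these few. Any claim that something is new, unique, unknown or untested is made for them only; others in the source may bear on it.

Measured compounds:
compound 1 `C/N=C(\S)n1nc(Oc2ccccc2)nc1N`: 5%
compound 2 `Cn1cnc2nc(-c3ccc(Cl)cc3)nn2c1=S`: 90%

In a functional assay on the whole organism for inhibition, with Rattus norvegicus as the target, at a dose of 3 mg/kg by the intraperitoneal route (a lower number here means less inhibition, a higher number more inhibition at the dose given (going by the name of the read-out)), compound 2 gives 90%, the highest of the two numbers; the nearest, compound 1, gives 5%, a gap beyond the scatter. Going by the values given here, the two compounds share no common core and no step between them is recorded, so only their two values are known.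

Compound 3 `Cn1cnc2nc(-c3ccc(F)cc3)nn2c1=S` carries the change (fluoro in place of chloro on an aromatic carbon). Among the compounds with values here, no measured pair shows this change. The expected step in this assay from compound 2 to compound 3 is estimated as a number 15 percentage points lower from compound 2 to compound 3 (beyond the scatter), a modest fall that may or may not exceed the scatter. For compound 3 the estimate is 75%, between 45% and 95%.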

Compound 3, a percentage reported as inhibition, in the whole organism at one dose (the size of the read-out at that dose, not a potency): 38%
For compound 3 the middle estimate is 37 percentage points above the measured one, and the stated range ends above it.
By their numbers in this assay, from the lowest: compound 1; then compound 3; then compound 2.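

Fluoro in place of chloro on the aromatic carbon para to a large group gives a number 52 percentage points lower from compound 2 to compound 3 (beyond the scatter) in this assay, so this position responds strongly to the identity of the halogen, even though the counted donors, acceptors and charge stay the same. In this single pair, chloro keeps more inhibition at the dose given than fluoro. Nothing available bears on the reason for this step.

The compounds shown leave open how a methoxy group, an amine or a nitrile at this place would compare with chloro. From the compounds shown here alone, whether the chloro to fluoro step carries over to other cores also remains open.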